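The source may hold more compounds than are shown below. What is called first, only, known or untested is meant among the compounds shown, and "the series" means these compounds.

Of the compounds shown here, three have so far been measured in a functional assay on NUGC-3 cells (Homo sapiens) for cytotoxicity, read by sulforhodamine B assay, with a stated time of 72 h; a higher number here means a weaker inhibitor of growth, a lower number a stronger inhibitor of growth. Compound 1 `O=C(Nc1ccccc1C(F)(F)F)C1CCc2ccccc2N1C(=O)c1ccccc1` gives 8120 nM, and compound 2 `CCCCCCCCC(=O)N1c2ccccc2CCC1C(=O)Nc1ccccc1C(F)(F)F` gives 6180 nM; the step of a 1.3-fold lower number from compound 1 to compound 2 (0.12 log units; within the scatter) lies within the scatter. Compound 3 `CCCC(=O)N1c2ccccc2CCC1C(=O)Nc1ccccc1C(F)(F)F` sits at the limit of > 70000 nM in this assay, at which 1 of the 3 values shown sits: its reading of > 70000 nM is a limit of the assay and not a number. The steps of an at least 8.6-fold higher number from compound 1 to compound 3 (0.93 log units; beyond the scatter) and an at least 11-fold higher number from compound 2 to compound 3 (1.05 log units; beyond the scatter) both run toward weaker growth inhibition, and compound 3 stands as the weakest of the three, its step from each of the others beyond the scatter.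

Compound 4 `CC(=O)N1c2ccccc2CCC1C(=O)Nc1ccccc1C(F)(F)F` has not yet been measured. It differs from compound 3 by hydrogen in place of ethyl on a saturated chain carbon bound to a carbonyl carbon. The step from compound 2 to compound 3 shortened the chain on the carbonyl carbon and raised the number beyond the scatter; the present change shortens that chain further, from propylcarbonyl to acetyl. Among the compounds with values here, because compound 3 already sits at the limit of > 70000 nM in this assay, at which 1 of the 3 values shown sits, no measured step shows what happens past that point, and the step of a number no higher from compound 3 to compound 4 (the limit leaves the size open) is expected to be flat or upward rather than a fall beyond the scatter. Compound 4 is therefore estimated at about 70000 nM, between 20000 nM and 250000 nM, and most likely reported again only as a limit.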

Compound 4, concentration for 50% growth inhibition: > 80000 nM
Compound 4 ended at the assay's limit (the forecaster's own chance of this, stated with the estimate: 65%); middle value at least 1.1-fold (0.05 log units) from the limit.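

In this assay, the reading of compound 4, which carries acetyl on the shared core, is a limit of the assay and not a number: the limit of > 80000 nM in this assay, at which 1 of the 4 values shown sits. The step from compound 3 to compound 4, hydrogen in place of ethyl on a saturated chain carbon bound to a carbonyl carbon, cannot be read, as both of its readings are limits. Measured against the two compounds that have numbers, the result gives an at least 12-fold higher number from compound 2 to compound 4 (1.11 log units; beyond the scatter) and an at least 9.8-fold higher number from compound 1 to compound 4 (0.99 log units; beyond the scatter), so the loss of growth inhibition seen with propyl on the carbonyl carbon persists with methyl there, and going shorter than propyl brings no return of growth inhibition within the range this assay reads.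

The compounds shown leave open at which chain length, from butyl up to heptyl on the carbonyl carbon, the reading turns, and whether a chain longer than octyl goes further. They also leave open whether an amine or a carboxylic acid on that chain would keep growth inhibition at the level of compound 1 and compound 2.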